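The source may report more compounds than this note shows. Statements on the series, on what has been measured and on what is new or still open speak of the compounds shown alone.

Working notes on the series in a functional assay on the whole organism (Tail, strain ICR) with Mus musculus as the target, in the tail flick test, with a stated time of 30 min, at a dose of 25 umol/kg by the oral route; a lower number here means a weaker effect, a higher number a stronger effect of the compound at the dose given.

Among the compounds with values here, compound 3 `NC(=O)C[C@H](NC(=O)CN(c1ncnc2c1ncn2C1CCCCO1)C1CC1)C(=O)OCc1ccccc1` gives 34.5% in this assay, the highest of the three numbers measured so far. Compound 2 `O=C(CN(c1ncnc2c1ncn2C1CCCCO1)C1CC1)N[C@@H](CCC(=O)OCc1ccccc1)C(=O)OCc1ccccc1` gives 32.6%, and the gap between compound 2 and compound 3 lies within the scatter, so no order between these two can be read. Compound 1 `CC(C)[C@H](NC(=O)CN(c1ncnc2c1ncn2C1CCCCO1)C1CC1)C(=O)OCc1ccccc1` gives 21.8%, and the step of a number 12.7 percentage points higher from compound 1 to compound 3 (beyond the scatter) is beyond the scatter, as is the step of a number 10.8 percentage points higher from compound 1 to compound 2 (beyond the scatter). The step of a number 1.9 percentage points higher from compound 2 to compound 3 (within the scatter) is within the scatter.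

Compound 4 `CC(C)C[C@H](NC(=O)CN(c1ncnc2c1ncn2C1CCCCO1)C1CC1)C(=O)OCc1ccccc1` has not yet been measured. It differs from compound 3 as follows: isopropyl in place of carbamoyl on a saturated chain carbon, two bonds along the chain from an amide-type nitrogen and a carbonyl carbon. The measured step that bears on it is the step of a number 12.7 percentage points higher from compound 1 to compound 3 (beyond the scatter), which introduced the carbamoylmethyl group in place of isopropyl; compound 4 removes the carbamoyl again, leaving isobutyl rather than isopropyl, so the comparison is not exact. A modest drop is expected in this assay, roughly reversing that step. For compound 4 the estimated value is 24%, within 14% to 34%. This estimate implies the expected step of a number 10.5 percentage points lower from compound 3 to compound 4 (beyond the scatter).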

Compound 4, a percentage reported as activity, at one dose (the size of the read-out at that dose, not a potency): 26.2%
Compound 4: middle estimate off by 2.2 percentage points, on the low side; low and high end bracket the measured number.
By their numbers in this assay, from the lowest: compounds 1, 4, 2 and 3 (each within the scatter of the next, the first and the last beyond it).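

At this position, in this assay, the isobutyl of compound 4 cannot be separated from carbamoylmethyl (a number 8.3 percentage points lower from compound 3 to compound 4 (within the scatter)), from 2-(benzyloxycarbonyl)ethyl (a number 6.4 percentage points lower from compound 2 to compound 4 (within the scatter)) or from isopropyl (a number 4.4 percentage points higher from compound 1 to compound 4 (within the scatter)). The earlier compounds set isopropyl apart from both other side chains, but compound 4 now links the two ends of the series through steps that each stay within the scatter, so the carbamoyl is not shown to be required and the side chains do not fall into two distinct groups. Nothing available explains these numbers. Still open, as far as these compounds go, is whether an amine, a carboxylic acid or a longer alkyl chain on this saturated chain carbon would stand beyond the scatter of all four compounds. Replicate measurements would be needed to place compound 4 more firmly among them.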